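This account rests on a few compounds, and the source may have more. Where it says the series, first, only, none or still open, it means among the compounds named here.

Compound 1 `CSc1ccc(-c2cccc(NC(=O)CCc3cccc4c3B(O)OC4)c2)cc1`: 140 nM
Compound 2 `O=C(CCc1cccc2c1B(O)OC2)Nc1cccc(-c2cccc(C(F)(F)F)c2)c1`: 390 nM

For the measured compounds named here, in a functional assay on SK-OV-3 cells (Homo sapiens) for antiproliferative activity, read by MTT assay, with a stated time of 72 h (on this read-out lower numbers stand for stronger inhibition and higher numbers for weaker inhibition), compound 2 gives 390 nM, the higher of the two numbers measured so far. Compound 3 `CC(=O)c1cccc(-c2cccc(NC(=O)CCc3cccc4c3B(O)OC4)c2)c1` carries acetyl in place of trifluoromethyl on an aromatic carbon, meta to a large group (acetyl in place of trifluoromethyl on an aromatic carbon). Going by the values given here, the only measured step that bears on this change is a 2.8-fold higher number from compound 1 to compound 2 (0.44 log units; beyond the scatter), a modest one that also alters this aromatic substituent. A step no larger than that is therefore expected in this assay, leaning slightly towards a lower number. The expected step is a 1.5-fold lower number from compound 2 to compound 3 (0.18 log units; within the scatter). For compound 3 the estimate is 260 nM, within an expected range of 90 nM to 750 nM.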

Compound 3, half-maximal inhibitory concentration: 68 nM
Estimate against measurement, compound 3: 3.8-fold (0.58 log units) above; measured number below the stated range.
By their numbers in this assay, from the lowest: compound 3; then compound 1; then compound 2.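

In this assay, acetyl in place of trifluoromethyl on this aromatic carbon gives a 5.7-fold lower number from compound 2 to compound 3 (0.76 log units; beyond the scatter), so this position responds to the choice of group more strongly than the earlier pair alone could show. The 3-acetylphenyl group also outperforms 4-(methylsulfanyl)phenyl, with a 2.1-fold lower number from compound 1 to compound 3 (0.31 log units; beyond the scatter), which makes compound 3 the strongest of the three. Nothing available explains why the acetyl compound stands lowest. The compounds shown leave open whether the carbonyl of acetyl is what matters. A methyl ester, a nitrile or a primary amide at this place would test that.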